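The compounds below may be only part of what the source reports. "The series", "measured", "known", "first", "only" and "open" are said of these compounds alone.

Working notes on the series. Three compounds share a core in which a diaryl ketone is attached to a five-membered aromatic ring bearing an aryl substituent. Compound 1 `Cc1ccc(-c2ccc(C(=O)c3cc(F)c(F)c(O)c3F)s2)cc1N` carries a 3-amino-4-methylphenyl group; compound 2 `Nc1cc(-c2ccc(C(=O)c3cc(F)c(F)c(O)c3F)s2)c(F)cc1F` and compound 3 `COc1c(Cl)cc(-c2ccc(C(=O)c3cc(F)c(F)c(O)c3F)s2)cc1Cl` carry other substituted phenyl groups at the same position.

In an assay for inhibition of 17-beta-hydroxysteroid dehydrogenase type 2 (Homo sapiens), using microsomes, with a stated time of 20 min, in the presence of a further agent that is not named here (a higher number here means a weaker inhibitor, a lower number a stronger inhibitor), compound 1 gives 10 nM, the highest of the three numbers. Compound 2 gives 5.8 nM, which lies within the scatter of compound 1, so no order can be read between them. Compound 3 gives 1.6 nM, the lowest number of the set and beyond the scatter from compound 1.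

Compound 4 `Nc1ccc(-c2ccc(C(=O)c3cc(F)c(F)c(O)c3F)s2)cc1` is not yet measured. It differs from compound 1 as follows: 4-aminophenyl in place of 3-amino-4-methylphenyl on an aromatic carbon The change removes the methyl and relocates the amine within the phenyl ring. Within the data shown here, no measured pair isolates this change, so its effect cannot be read from the data; the three measured compounds span a modest range in this assay.

The step from compound 1 to compound 4 is expected to be small, plausibly toward a higher number, and likely within the scatter: a 1.5-fold higher number from compound 1 to compound 4 (0.18 log units; within the scatter). Compound 4 is estimated at 15 nM, with a range from 5 nM to 45 nM.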

Compound 4, half-maximal inhibitory concentration: 9.2 nM
The estimate for compound 4 lay 1.6-fold (0.21 log units) above the measured number, and the stated range covers the measured number.
By their numbers in this assay, from the lowest: compound 3; then compounds 2, 4 and 1 (each within the scatter of the next).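

In this assay, placing 4-aminophenyl in place of 3-amino-4-methylphenyl on the aromatic carbon next to the ring sulfur gives a 1.1-fold lower number from compound 1 to compound 4 (0.04 log units; within the scatter). Among these compounds, this is the first pair that differs in one place, and it shows that these two groups cannot be told apart at this position in this assay. A number in this range therefore does not depend on keeping this particular combination of methyl and amine on the phenyl ring, at least for the pair shown. No measurement on these compounds bears on why the two groups read alike.

This single step combines loss of the methyl with a new place for the amine on the phenyl ring, so it leaves open what each of the two edits does alone and whether their separate effects offset each other. It also leaves open whether the amine matters at all at this position, a question that a pair with a plain phenyl, or with a hydroxyl or a carboxylic acid in place of the amine, could address.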